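The source may report more compounds than this note shows. Statements on the series, on what has been measured and on what is new or still open speak of the compounds shown alone.

Measured so far in an ADME assay on Vero cells (Chlorocebus sabaeus) for cytotoxicity; a higher number here means that more compound is tolerated, a lower number that less compound is tolerated:
Compound 1 `CCC(=O)Nc1ccc(-c2nc3cc(C(F)(F)F)ccc3[nH]2)cc1` gives > 100000 nM, which is a limit of the assay rather than a number.
Compound 2 `CCC(=O)Nc1ccc(-c2nc3cc(C(F)(F)F)ccc3n2C)cc1` gives > 100000 nM, also a limit.
Compound 3 `Cn1c(-c2ccc(NC(=O)CN3CCN(c4ccccc4)CC3)cc2)nc2cc(C(F)(F)F)ccc21` gives 30000 nM.

The core of compound 3 differs from that of compound 2 by 4-phenylpiperazin-1-yl in place of methyl on a saturated chain carbon bound to a carbonyl carbon, and this brought an at least 3.3-fold lower number from compound 2 to compound 3 (0.52 log units; beyond the scatter). Compound 2 and compound 1 differ by hydrogen in place of methyl on an aromatic nitrogen; the step that the two limits leave unreadable from compound 2 to compound 1 cannot be sized because of the limit of > 100000 nM in this assay, at which 2 of the 3 values shown sit. Compound 4 `O=C(CN1CCN(c2ccccc2)CC1)Nc1ccc(-c2nc3cc(C(F)(F)F)ccc3[nH]2)cc1` carries the same change against compound 3, (hydrogen in place of methyl on an aromatic nitrogen), made at the same place. For the measured compounds named here, with the one earlier example unreadable, the change is expected to move the value only a little, an estimated no change at the digits printed from compound 3 to compound 4 (within the scatter) set beside that earlier step. Compound 4 is therefore expected to come out near 30000 nM, somewhere between 10000 nM and 100000 nM.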

Compound 4, half-maximal cytotoxic concentration: > 100000 nM
Compound 4 gave a limit, no number (the forecaster's own chance of this, stated with the estimate: 20%); at least 3.3-fold (0.52 log units) between middle value and limit.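

In this assay, hydrogen in place of methyl on an aromatic nitrogen gave an at least 3.3-fold higher number from compound 3 to compound 4 (0.52 log units; beyond the scatter), so on this core the change moves the value beyond the scatter. Going by these compounds, compound 4 gives > 100000 nM, which is a limit of the assay and not a number, so the full size of this step stays unknown. This does not show that the change carries over from one core to another, because the matching step from compound 2 to compound 1 cannot be read: the limit of > 100000 nM in this assay, at which 3 of the 4 values shown sit.

On these data alone, it remains open whether the change would act the same way with a morpholine in place of the 4-phenylpiperazin-1-yl group. An ethyl group on that aromatic nitrogen is also left open.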